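Fluoro for isopropyl: expected return of maximal response

The source may hold more compounds than are shown below. What is called first, only, known or untested is meant among the compounds shown, and "the series" means these compounds.

Within the data shown here, in a functional assay on cells for agonist activity at G-protein coupled receptor 52 (Homo sapiens), read by AlphaScreen and cAMP accumulation, with a stated time of 30 min (a lower number here means a smaller maximal response, a higher number a larger maximal response), compound 2 `Cc1nc(Cc2cccc(C(F)(F)F)c2)sc1-c1ccc(C(N)=O)c(C(C)C)c1` gives 63%, the lower of the two numbers measured so far; compound 1 `Cc1nc(Cc2cccc(C(F)(F)F)c2)sc1-c1ccc(C(N)=O)cc1` gives 93%. Among the measured compounds shown here, the only step that bears on the next change is a number 30 percentage points lower from compound 1 to compound 2 (beyond the scatter), a modest loss. Compound 3 `Cc1nc(Cc2cccc(C(F)(F)F)c2)sc1-c1ccc(C(N)=O)c(F)c1` differs from compound 2 by fluoro in place of isopropyl on an aromatic carbon. Because compound 1 gives 93% with hydrogen at the same carbon, a partial recovery toward that value is expected for compound 3, amounting to a number 21 percentage points higher from compound 2 to compound 3 (beyond the scatter). Compound 3 is therefore estimated at 84%, within a range of 66% to 100%.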

Compound 3, largest response reached (Emax), in percent of the reference or control that the assay uses: 84%
For compound 3 middle estimate and measured number coincide at the digits printed; low and high end bracket the measured number.
By their numbers in this assay, from the lowest: compound 2; then compounds 3 and 1 (each within the scatter of the next).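

In this assay, this carbon accepts a substituent without a loss of maximal response: a number 9 percentage points lower from compound 1 to compound 3 (within the scatter). The loss seen with isopropyl therefore does not extend to every group here, as shown by a number 21 percentage points higher from compound 2 to compound 3 (beyond the scatter). Nothing available explains why isopropyl and fluoro differ.

On these data alone, whether a methyl, a methoxy or a chloro group at this carbon, ortho to a carbamoyl group, would track compound 3 or compound 2 remains open. Fluoro and isopropyl alone do not define a trend across substituents.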